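Working notes: a second chloro on the aryl ring

The source may hold more compounds than are shown below. What is called first, only, known or untested is meant among the compounds shown, and "the series" means these compounds.

Measured so far:
compound 1 `O=C1/C(=C/c2ccccc2Cl)Cc2ccccc21` gives 128000 nM
compound 2 `O=C1/C(=C/c2ccccc2F)Cc2ccccc21` gives 54200 nM

Among the compounds with values here, in a functional assay on Molt4/C8 cells (Homo sapiens) for inhibition (a lower number here means a stronger inhibitor, a higher number a weaker inhibitor), compound 1 stands at the highest of the two numbers; the one step measured, a 2.4-fold lower number from compound 1 to compound 2 (0.37 log units; beyond the scatter), is fluoro in place of chloro on an aromatic carbon. Compound 3 `O=C1/C(=C/c2ccc(Cl)cc2Cl)Cc2ccccc21` differs from compound 1 by chloro in place of hydrogen on an aromatic carbon. Within the data shown here, no measured step concerns an added chloro: the step of a 2.4-fold lower number from compound 1 to compound 2 (0.37 log units; beyond the scatter) exchanges the existing halogen and does not bear on this change. Therefore no step beyond the scatter is expected. Compound 3 is estimated at 100000 nM, with a range of 40000 nM to 250000 nM, which means an expected 1.3-fold lower number from compound 1 to compound 3 (0.11 log units; within the scatter).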

Compound 3, half-maximal inhibitory concentration: > 500000 nM
Compound 3: only a limit was reported; the forecaster's own chance of this, stated with the estimate: 25%; middle value at least 5.0-fold (0.69 log units) away from the limit.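

In this assay, chloro in place of hydrogen on the aromatic carbon para to a large group gives an at least 3.9-fold higher number from compound 1 to compound 3 (0.59 log units; beyond the scatter). The earlier step only exchanged one halogen for another; this is the first added group shown, and it moves toward weaker inhibition. Compound 3 has only a limit, not a number: the limit of > 500000 nM in this assay, at which 1 of the 3 values shown sits.

Open, from the compounds shown here alone, is whether this shift belongs to chloro or to any group at this place, such as fluoro, an amine or a carboxylic acid. Also open, going by these compounds, is how an added chloro behaves elsewhere on the aryl ring.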